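The source may report more compounds than this note shows. Statements on the series, on what has been measured and on what is new or still open speak of the compounds shown alone.

Of the compounds shown here, two have been measured in an assay on isolated protein for inhibition of Nitric oxide synthase, inducible (Homo sapiens), with a stated time of 30 min, tested at 1 mM; on this read-out lower numbers stand for less inhibition and higher numbers for more inhibition at the one concentration tested (going by the name of the read-out). Compound 1 `Nc1ccc(Cl)cc1C1=NN(C(=O)C2CC2)CC1` gives 18.9% in this assay, and compound 2 `CCCCC(=O)N1CCC(c2cc(OC)ccc2N)=N1` gives 0.18%. Compound 2 thus stands at the lower of the two numbers, and compound 1 lies above it by a gap that is beyond the scatter of this kind of measurement. The next compound, compound 3 `COc1ccc(N)c(C2=NN(C(=O)C3CC3)CC2)c1`, shares its core with compound 2 and differs in one place: cyclopropyl in place of butyl on a carbonyl carbon. For the measured compounds named here, no measured pair shows this particular change on its own, so its effect on the read-out is not yet known from the data. Compound 3 is therefore expected to stay close to compound 2, with a step of a number 4.8 percentage points higher from compound 2 to compound 3 (within the scatter) that may well lie within the scatter, leaning slightly upward. The estimate for compound 3 in this assay is 5%, expected between 0% and 20%.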

Compound 3, a percentage reported as inhibition, at one concentration (the size of the read-out at that concentration, not a potency): 19.9%
Estimate against measurement, compound 3: 14.9 percentage points below; low and high end bracket the measured number.
By their numbers in this assay, from the lowest: compound 2; then compounds 1 and 3 (each within the scatter of the next).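

In this assay, for the compounds shown here, putting cyclopropyl in place of butyl on a carbonyl carbon, with the rest of the molecule unchanged, gives a number 19.7 percentage points higher from compound 2 to compound 3 (beyond the scatter) and so shows that the group at this position can move the read-out, which the earlier compounds could not show on their own. Methoxy in place of chloro on an aromatic carbon gives a number 1 percentage points higher from compound 1 to compound 3 (within the scatter) and so leaves these two groups indistinguishable here, at least with cyclopropylcarbonyl in place. Nothing available explains the effect of the cyclopropyl group.

From the compounds shown here alone, it remains open whether the gain belongs to the three-membered ring itself or would also appear with a cyclobutyl ring, an isopropyl group or a shorter chain such as ethyl. Also open, going by these compounds, is whether chloro and methoxy would still match with butyl on the carbonyl carbon.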